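From an Isobutyl Chain to a Phenyl Ring

The compounds below may be only part of what the source reports. "The series", "measured", "known", "first", "only" and "open" are said of these compounds alone.

Of the compounds shown here, three sharing one core have been tested in a functional assay on HL-60 cells (Homo sapiens) for antiproliferative activity, read by MTT assay; a higher number here means a weaker inhibitor, a lower number a stronger inhibitor. Compound 1 `C#CC[C@@H]1O[C@H](COCc2ccccc2)[C@@H](OCc2ccccc2)[C@H](OCc2ccccc2)[C@H]1O` is reported in that assay as "not active" (no number reported), without a number. Compound 2 `C=CC[C@@H]1O[C@H](COCc2ccccc2)[C@@H](OCc2ccccc2)[C@H](OCc2ccccc2)[C@H]1O` gives in this assay 15100 nM. Compound 3 `CC(C)C[C@@H]1O[C@H](COCc2ccccc2)[C@@H](OCc2ccccc2)[C@H](OCc2ccccc2)[C@H]1O` gives in this assay 8500 nM. Going by the values given here, compound 3 thus has the lowest of the two numbers reported, but the only single-point step among the measured compounds, a 1.8-fold lower number from compound 2 to compound 3 (0.25 log units; within the scatter), is within the scatter, so compound 2 and compound 3 cannot be told apart on these data, and compound 1 stands aside without a number.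

Compound 4 `O[C@@H]1[C@@H](OCc2ccccc2)[C@H](OCc2ccccc2)[C@@H](COCc2ccccc2)O[C@H]1c1ccccc1` is the next member. Its change from compound 3 is phenyl in place of isobutyl on a saturated ring carbon. Among the compounds with values here, no measured step replaces a chain with an aromatic ring, and the one step that is known, isopropyl in place of vinyl, stayed within the scatter. Nothing in the data therefore points to a change in this assay beyond the scatter in either direction, and the expectation for compound 4 must be wide. The expected step is a 1.2-fold lower number from compound 3 to compound 4 (0.08 log units; within the scatter), a small one. In this assay compound 4 is estimated at 7000 nM, with a range from 2000 nM to 30000 nM.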

Compound 4, half-maximal inhibitory concentration: 26300 nM
Estimate against measurement, compound 4: 3.8-fold (0.57 log units) below, and the stated range covers the measured number.
By their numbers in this assay, from the lowest: compounds 3, 2 and 4 (each within the scatter of the next, the first and the last beyond it).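

Going by these compounds alone, the exchange at the saturated ring carbon next to the ring oxygen produces the first step that lies beyond the scatter: in this assay the move to phenyl gives a 3.1-fold higher number from compound 3 to compound 4 (0.49 log units; beyond the scatter) and so shows, if only modestly, that the number can respond to the group held at this position. The same exchange measured from the allyl compound gives a 1.7-fold higher number from compound 2 to compound 4 (0.24 log units; within the scatter) and stays inside the scatter, so the phenyl compound stands apart from the isobutyl compound but cannot be told apart from the allyl compound, and the effect of the change depends on the chain used for comparison. No evidence is available that would account for this difference.

The compounds shown leave open whether the aromatic ring itself or simply a group of this size goes with the higher number, a question that a cyclohexyl group at the same carbon could address. They also leave open how a phenyl ring bearing an amine or a carboxylic acid would read, and whether a chain longer than isobutyl would separate from compound 3.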